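Adding Trifluoromethyl to a Compound at the Limit

The compounds below may be only part of what the source reports. "The series", "measured", "known", "first", "only" and "open" are said of these compounds alone.

In a functional assay on MT4 cells (Homo sapiens) for cytotoxicity (a lower number here means a stronger inhibitor, a higher number a weaker inhibitor), compound 1 `COc1cccc(S(=O)(=O)c2cccc(N)c2C#N)c1` gives > 200000 nM, which is a limit of the assay and not a number. Compound 2 `N#Cc1cccc(S(=O)(=O)c2cccc(N)c2C#N)c1` gives > 200000 nM, again only a limit. All the evidence so far is the limit of > 200000 nM in this assay, at which 2 of the 2 values shown sit. Compound 3 `COc1cc(C(F)(F)F)cc(S(=O)(=O)c2cccc(N)c2C#N)c1` keeps the core of compound 1 and changes it in one place: trifluoromethyl in place of hydrogen on an aromatic carbon. Among the compounds with values here, the only measured step that bears on this is a step that the two limits leave unreadable from compound 1 to compound 2, in which cyano takes the place of methoxy. Its size cannot be read, and it involves a different change, so it offers no size to carry over. Only a small shift is therefore expected, and another reading at the limit would be no surprise. The expected step is an at least 1.3-fold lower number from compound 1 to compound 3 (0.12 log units; that floor lies within the scatter). For compound 3 the estimate is 150000 nM, with an expected range of 50000 nM to 300000 nM.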

Compound 3, half-maximal inhibitory concentration: 164000 nM
Compound 3: the middle estimate sits 1.1-fold (0.04 log units) below what was measured; measured number inside the range.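

Trifluoromethyl in place of hydrogen at this aromatic carbon gives the only reading in this assay that is a number and not a limit. From the compounds shown here alone, the step is an at least 1.2-fold lower number from compound 1 to compound 3 (0.08 log units; that floor lies within the scatter), and only this floor can be read, so its true size stays unknown. The other two compounds still give only a limit: the limit of > 200000 nM in this assay, at which 2 of the 3 values shown sit.

The compounds shown leave open whether a methyl group, a chlorine atom or an amine on this same carbon would also give a number rather than a limit. They also leave open whether trifluoromethyl would do the same on compound 2, where cyano stands in place of methoxy.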